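Branching a Short Side Chain in a Cell-Growth Inhibitor

The compounds below may be only part of what the source reports. "The series", "measured", "known", "first", "only" and "open" are said of these compounds alone.

Compound 1 `CCCC(C#CC(=O)OC)O/C=C/C(=O)OC` was tested in a functional assay on SW1573 cells (Homo sapiens) for antiproliferative activity, read by sulforhodamine B assay, with a stated time of 48 h (a lower number here means a stronger inhibitor of growth, a higher number a weaker inhibitor of growth), where compound 1 gives 320 nM. Among the values shown, this is the only real number. Compound 2 `CC1CCC(C(C)C)C(OC(=O)C#CC(O/C=C/C(=O)OC2CC(C)CCC2C(C)C)C(C)C)C1` reaches in this assay only a limit, > 100000 nM, and no number. The set therefore holds (the limit of > 100000 nM in this assay, at which 1 of the 2 values shown sits). For the measured compounds named here, no pair of measured compounds differs in a single place, so no measured step shows how a small change in one group shifts growth inhibition here.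

Compound 3 `COC(=O)C#CC(O/C=C/C(=O)OC)C(C)C` is built from the same atoms as compound 1, joined differently: isopropyl in place of propyl on a saturated chain carbon bound to an oxygen on an unsaturated carbon and a triple-bonded carbon. The group that leaves and the group that enters are the same size and carry no donors, acceptors or charge, so the change is expected to be small. The step of a 1.3-fold higher number from compound 1 to compound 3 (0.10 log units; within the scatter) is expected to stay within the usual scatter of this assay. Compound 3 is accordingly estimated at 400 nM, with a likely range from 150 nM to 1100 nM.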

Compound 3, concentration for 50% growth inhibition: 750 nM
The estimate for compound 3 lay 1.9-fold (0.27 log units) below the measured number, and the stated range covers the measured number.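

For the compounds shown here, this is the first measured step in the set. It shows that the position on the saturated chain carbon responds to the shape of the group it carries, not only to its atoms: with the same atoms joined differently, isopropyl in place of propyl gives, in this assay, a 2.3-fold higher number from compound 1 to compound 3 (0.37 log units; beyond the scatter), a modest loss of growth inhibition. Nothing measured here accounts for this shift.

The compounds shown leave open how a longer chain, such as butyl, or a more heavily branched group, such as tert-butyl, would behave at this position. A single step also cannot show whether the effect of branching would hold on a different core, or whether a group carrying an amine would be tolerated here.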